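Swapping iodo for methyl on the anilide series

The compounds below may be only part of what the source reports. "The series", "measured", "known", "first", "only" and "open" are said of these compounds alone.

Measured in a functional assay on SK-OV-3 cells (Homo sapiens) for antiproliferative activity, read by MTT assay, with a stated time of 72 h; on this read-out lower numbers stand for stronger inhibition and higher numbers for weaker inhibition
- compound 1 `O=C(CCc1cccc2c1B(O)OC2)NC1CCCCC1` gives > 100000 nM as a limit
- compound 2 `O=C(CCc1cccc2c1B(O)OC2)Nc1nccs1` gives > 100000 nM as a limit
- compound 3 `O=C(CCc1cccc2c1B(O)OC2)Nc1ccc(I)cc1` gives 51000 nM as a true number

Among the compounds with values here, compound 3 is the only compound here with a true number. The rest of the series stands at the limit of > 100000 nM in this assay, at which 2 of the 3 values shown sit, and offers no number to rank against.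

Compound 4 `Cc1ccc(NC(=O)CCc2cccc3c2B(O)OC3)cc1` carries methyl in place of iodo on an aromatic carbon, para to a large group methyl in place of iodo on an aromatic carbon in the same difference.

Within the data shown here, no measured step replaces the iodo itself. The nearest evidence is an at least 1.9-fold lower number from compound 1 to compound 3 (0.29 log units; that floor lies within the scatter) and an at least 1.9-fold lower number from compound 2 to compound 3 (0.29 log units; that floor lies within the scatter), both swaps of the whole group on the amide-type nitrogen. A small move toward weaker inhibition is therefore expected, estimated as a 1.5-fold higher number from compound 3 to compound 4 (0.17 log units; within the scatter) overall. Compound 4 is estimated at 75000 nM with an expected range from 35000 nM to 150000 nM and could also read only as a limit.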

Compound 4, half-maximal inhibitory concentration: 860 nM
Estimate against measurement, compound 4: 87-fold (1.94 log units) above, and the stated range ends above it.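

In this assay, within the data shown here, the group on this aromatic carbon, para to a large group, matters far more than the earlier compounds could show: methyl in place of iodo gives a 59-fold lower number from compound 3 to compound 4 (1.77 log units; beyond the scatter). With 4-methylphenyl on the amide-type nitrogen, the series also separates clearly from the other two groups, with an at least 110-fold lower number from compound 2 to compound 4 (2.06 log units; beyond the scatter) and an at least 110-fold lower number from compound 1 to compound 4 (2.06 log units; beyond the scatter). Those two steps are floors and not sizes, because compound 1 and compound 2 read only as limits: the limit of > 100000 nM in this assay, at which 2 of the 4 values shown sit.

Why this single swap acts so strongly stays open. So does whether a methoxy, an amine or a longer chain on the same carbon would keep the lower number.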